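The compounds below may be only part of what the source reports. "The series", "measured", "known", "first", "only" and "open" are said of these compounds alone.

In a functional assay on HeLa cells (Homo sapiens) for inhibition, read by MTT assay, with a stated time of 48 h (on this read-out higher numbers stand for weaker inhibition and lower numbers for stronger inhibition), compound 1 (`Brc1ccc2[nH]cc(C(c3ccccc3)c3c[nH]c4ccc(Br)cc34)c2c1`) gives 900 nM, compound 2 (`COc1ccc(C(c2c[nH]c3ccc(Br)cc23)c2c[nH]c3ccc(Br)cc23)cc1`) gives 5500 nM and compound 3 (`Brc1ccc2[nH]cc(C(c3ccc4ccccc4c3)c3c[nH]c4ccc(Br)cc34)c2c1`) gives 4300 nM. Compound 3 thus stands alongside compound 2, and both show weaker inhibition than compound 1. Compound 4 (`CCCC(c1c[nH]c2ccc(Br)cc12)c1c[nH]c2ccc(Br)cc12`) has propyl in place of naphthalen-2-yl on a saturated chain carbon bound to two aromatic carbons. Within the data shown here, no measured compound carries a chain there, so the guidance is loose. Naphthalen-2-yl in place of phenyl gave a 4.8-fold higher number from compound 1 to compound 3 (0.68 log units; beyond the scatter), and methoxy in place of hydrogen gave a 6.1-fold higher number from compound 1 to compound 2 (0.79 log units; beyond the scatter). Both steps were modest, while a 1.3-fold lower number from compound 2 to compound 3 (0.11 log units; within the scatter) stayed within the scatter. The expected change is a 1.7-fold lower number from compound 3 to compound 4 (0.24 log units; within the scatter), a small move towards stronger inhibition that stays within the scatter. Compound 4 is estimated at 2500 nM, with an expected range from 800 nM to 7500 nM.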

Compound 4, half-maximal inhibitory concentration: 3900 nM
Compound 4: the middle estimate sits 1.6-fold (0.19 log units) below what was measured, within the range that was stated.
By their numbers in this assay, from the lowest: compound 1; then compounds 4, 3 and 2 (each within the scatter of the next).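

A chain can sit at this position: propyl matches the larger aromatic groups in this assay, with both steps within the scatter (a 1.1-fold lower number from compound 3 to compound 4 (0.04 log units; within the scatter); a 1.4-fold lower number from compound 2 to compound 4 (0.15 log units; within the scatter)). Phenyl alone stands apart from all three other groups, and the chain does not recover its stronger inhibition (a 4.3-fold higher number from compound 1 to compound 4 (0.64 log units; beyond the scatter)). Nothing available explains why phenyl differs from the other groups. From the compounds shown here alone, how an amine, a carboxylic acid or a longer chain would behave on this saturated chain carbon stays open. So does whether a smaller chain such as methyl would come closer to phenyl.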